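Working notes on the series: hydroxy to nitro

The source may hold more compounds than are shown below. What is called first, only, known or untested is meant among the compounds shown, and "the series" means these compounds.

Measured compounds in an assay for binding affinity to dual specificity mitogen-activated protein kinase kinase 4 (Homo sapiens), read by KINOMEscan, tested at 100 nM; a higher number here means a weaker effect of the compound at the concentration tested, a lower number a stronger effect:
- compound 1, `CCCS(=O)(=O)Nc1ccc(F)c(C(=O)c2n[nH]c3ncc(-c4ccccc4OC)cc23)c1F`: 1.9%
- compound 2, `CCCS(=O)(=O)Nc1ccc(F)c(C(=O)c2n[nH]c3ncc(-c4ccc(O)cc4)cc23)c1F`: 0.75%

Compound 2 shows the lower of the two numbers in this assay, but the gap to compound 1, a number 1.2 percentage points lower from compound 1 to compound 2 (within the scatter), lies within the scatter, so the two cannot be ordered.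

The next compound is compound 3, `CCCS(=O)(=O)Nc1ccc(F)c(C(=O)c2n[nH]c3ncc(-c4ccc([N+](=O)[O-])cc4)cc23)c1F`. It differs from compound 2 by nitro in place of hydroxy on an aromatic carbon.

For the measured compounds named here, only one measured step bears on this change: a number 1.2 percentage points lower from compound 1 to compound 2 (within the scatter), which swapped one substituted phenyl for another at the same aromatic carbon and produced no step beyond the scatter. Both compounds give numbers near the floor of this assay, so there is little room for a lower number and the main uncertainty is upward. No step beyond the scatter is expected, with a number 1.8 percentage points higher from compound 2 to compound 3 (within the scatter) as the estimated change. Compound 3 is expected to give 2.5%, in a range from 0.3% to 12%.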

Compound 3, a percentage reported as activity, at one concentration (the size of the read-out at that concentration, not a potency): 4.2%
The estimate for compound 3 lay 1.7 percentage points below the measured number; low and high end bracket the measured number.
By their numbers in this assay, from the lowest: compounds 2, 1 and 3 (each within the scatter of the next).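

In this assay, nitro in place of hydroxy, on an aromatic carbon para to a large group, gives a number 3.5 percentage points higher from compound 2 to compound 3 (within the scatter), and the wider swap of the whole aryl group gives a number 2.3 percentage points higher from compound 1 to compound 3 (within the scatter) as its result. This position therefore carries hydroxy, with its hydrogen-bond donor, and nitro, with none, without a step beyond the scatter, and the three compounds cannot be ordered. Nothing available bears on the cause of this result.

Still open, going by these compounds, is whether any group at this aromatic carbon moves the number beyond the scatter; an amine, a carboxylic acid or a longer chain in the place of hydroxy would test that. Also open, on these data alone, is whether hydroxy and nitro would separate in a true potency measurement, which a read-out at one concentration does not give.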